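Methoxyphenyl directly on the core in place of benzyl

A few compounds are considered here, and "the series" means these few. Any claim that something is new, unique, unknown or untested is made for them only; others in the source may bear on it.

Three analogues of one shared core have been run in a functional assay on CCRF-CEM cells (Homo sapiens) for inhibition, read by cell counting, with a stated time of 3 days; a higher number here means a weaker inhibitor, a lower number a stronger inhibitor. Compound 1 `C=C(Br)C(=O)Nc1cccc(-c2cn3nc(CCc4ccccc4)sc3n2)c1` gives 4200 nM, compound 2 `C=C(Br)C(=O)Nc1cccc(-c2cn3nc(Cc4ccc(OC)cc4)sc3n2)c1` gives 2300 nM, and compound 3 `C=C(Br)C(=O)Nc1cccc(-c2cn3nc(Cc4ccccc4)sc3n2)c1` gives 4200 nM. Compound 3 sits level with compound 1, the two together being the highest numbers of the three; the nearest is compound 1 with no change at the digits printed from compound 1 to compound 3 (within the scatter), the furthest is compound 2 with a 1.8-fold higher number from compound 2 to compound 3 (0.26 log units; within the scatter).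

Compound 4 `C=C(Br)C(=O)Nc1cccc(-c2cn3nc(-c4cccc(OC)c4)sc3n2)c1` differs from compound 3 by 3-methoxyphenyl in place of benzyl on an aromatic carbon. Going by the values given here, two measured steps bear on this. Shortening or lengthening the link between the core and the phenyl gave no change at the digits printed from compound 1 to compound 3 (within the scatter), and adding a methoxy on the aromatic ring gave a 1.8-fold higher number from compound 2 to compound 3 (0.26 log units; within the scatter); neither moved the number beyond the scatter. Among the compounds with values here, removing the chain carbon entirely and placing methoxyphenyl directly on the aromatic carbon has no exact precedent here, so the expectation rests on these two steps. The step expected is a 1.2-fold lower number from compound 3 to compound 4 (0.08 log units; within the scatter), that is, no change beyond the scatter. Compound 4 is therefore estimated at 3500 nM, with a range from 1500 nM to 8000 nM.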

Compound 4, half-maximal inhibitory concentration: 1200 nM
For compound 4 the middle estimate is 2.9-fold (0.46 log units) above the measured one; the measured number lies below the stated range.
By their numbers in this assay, from the lowest: compounds 4, 2, 1 and 3 (each within the scatter of the next, the first and the last beyond it).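

Going by these compounds alone, replacing benzyl with 3-methoxyphenyl on this aromatic carbon gives the first steps at this position that lie beyond the scatter in this assay: a 3.5-fold lower number from compound 3 to compound 4 (0.54 log units; beyond the scatter) and, against phenethyl, a 3.5-fold lower number from compound 1 to compound 4 (0.54 log units; beyond the scatter). Against 4-methoxybenzyl the picture differs, with a 1.9-fold lower number from compound 2 to compound 4 (0.28 log units; within the scatter), so compound 2 and compound 4 cannot be told apart, and a direct ring on the aromatic carbon is not separated here from a methoxy-bearing ring one chain carbon away. Nothing available explains the size of these steps.

This change removes the chain carbon and adds a methoxy at once, so the part each plays stays unresolved. Open, on these data alone, is how a plain phenyl, a 4-methoxyphenyl or a 3-aminophenyl on the same aromatic carbon would compare with compound 4.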